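Silyl ether analogues: aryl swap on the cyclopentenone core

This account rests on a few compounds, and the source may have more. Where it says the series, first, only, none or still open, it means among the compounds named here.

Compound 1 `COCOc1cc(C2=C(c3cc(OC)c(OC)c(OC)c3)C(=O)CC2O[SiH2]C(C)(C)C)ccc1OC`: 13.5 ug/mL
Compound 2 `COc1cc(C2=C(c3cc(C)c(OC)c(C)c3)C(OC(C)=O)CC2=O)cc(OC)c1OC`: > 100 ug/mL
Compound 3 `COc1cc(C2=C(c3ccccc3)C(O[SiH2]C(C)(C)C)CC2=O)cc(OC)c1OC`: > 100 ug/mL

In an ADME assay on PA-1 cells (Homo sapiens) for cytotoxicity, read by MTT assay, with a stated time of 72 h (on this read-out lower numbers stand for stronger inhibition and higher numbers for weaker inhibition), compound 3 reports only a limit, > 100 ug/mL, so no number stands for it. Compound 2 likewise gives only a limit, > 100 ug/mL. For the measured compounds named here, the one step that bears on the change is an at least 7.4-fold higher number from compound 1 to compound 3 (0.86 log units; beyond the scatter); the reverse direction, moving from phenyl to a substituted aryl, is what compound 4 `COc1cc(C2=C(c3cc(C)c(OC)c(C)c3)C(O[SiH2]C(C)(C)C)CC2=O)cc(OC)c1OC` undertakes: 4-methoxy-3,5-dimethylphenyl in place of phenyl on a double-bonded ring carbon. Compound 2, carrying the same aryl group with an acetate in place of the silyl ether, sits at the limit (the limit of > 100 ug/mL in this assay, at which 2 of the 3 values shown sit). Compound 4 is therefore expected to show a step of an at least 1.6-fold lower number from compound 3 to compound 4 (0.22 log units; that floor lies within the scatter) toward lower numbers in this assay, though the chance of another limit remains high. Compound 4 is estimated at 60 ug/mL, between 15 ug/mL and 150 ug/mL.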

Compound 4, half-maximal inhibitory concentration: 32 ug/mL
Estimate against measurement, compound 4: 1.9-fold (0.27 log units) above, within the range that was stated.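

In this assay, 4-methoxy-3,5-dimethylphenyl in place of phenyl on this double-bonded ring carbon turns a limit into a measured value, giving an at least 3.1-fold lower number from compound 3 to compound 4 (0.49 log units; beyond the scatter). With that aryl group unchanged, the silyl ether in place of the acetate gives an at least 3.1-fold lower number from compound 2 to compound 4 (0.49 log units; beyond the scatter), so both places bear on the read-out. Set against 4-methoxy-3-(methoxymethoxy)phenyl, however, the same aryl group gives a 2.4-fold higher number from compound 1 to compound 4 (0.37 log units; beyond the scatter).

On these data alone, the full size of the first two steps stays open, since compound 2 and compound 3 each give only a limit: the limit of > 100 ug/mL in this assay, at which 2 of the 4 values shown sit. Whether an aryl group bearing an amine or a carboxylic acid would give a lower number also remains open.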